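A nitrophenyl swap on compound 1

The compounds below may be only part of what the source reports. "The series", "measured", "known", "first", "only" and "open" are said of these compounds alone.

- Compound 1 `CN(C)c1ccc(C2CCCN2Cc2ccc(-c3ccccc3[N+](=O)[O-])o2)cc1`: 3.74 h
- Compound 2 `COc1ccc(C2CCCN2Cc2ccc(-c3ccccc3[N+](=O)[O-])o2)cc1`: 1.43 h

Both values come from an ADME assay on the whole organism (Mus musculus, strain CD-1) for metabolic stability, read by LC-MS, with a stated time of 7 h, at a dose of 40 mg/kg by the intraperitoneal route; a lower number here means that the compound disappears faster, a higher number that the compound lasts longer. Compound 1 stands higher of the two, at 3.74 h. Compound 3 `Cc1cc([N+](=O)[O-])ccc1-c1ccc(CN2CCCC2c2ccc(N(C)C)cc2)o1` keeps the rest of compound 1 and changes one group: 2-methyl-4-nitrophenyl in place of 2-nitrophenyl on an aromatic carbon. Within the data shown here, the only measured step, a 2.6-fold lower number from compound 1 to compound 2 (0.42 log units; beyond the scatter), is modest and swaps dimethylamino for methoxy, a different group from the one changing here. It therefore gives no direction for this change, and no clear shift beyond the scatter is expected in this assay. The expected step, an estimate only, is a 1.2-fold lower number from compound 1 to compound 3 (0.10 log units; within the scatter). Compound 3 is expected at 3 h, with an estimated range of 1.3 h to 7 h.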

Compound 3, half-life: 1.54 h
The estimate for compound 3 lay 1.9-fold (0.29 log units) above the measured number; the measured number falls inside the stated range.
By their numbers in this assay, from the lowest: compounds 2 and 3 (each within the scatter of the next); then compound 1.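

In this assay, putting 2-methyl-4-nitrophenyl in place of 2-nitrophenyl gives a 2.4-fold lower number from compound 1 to compound 3 (0.39 log units; beyond the scatter). So the group on this carbon, next to the ring oxygen, also affects how long the compound lasts, not only the dimethylamino group changed in compound 2. No measurement at hand explains the drop. As far as these compounds go, this swap adds the methyl and shifts the nitro group together, and the share of each remains open. Also open, from the compounds shown here alone, is how a phenyl ring carrying an amine or a carboxylic acid instead of the nitro group would behave.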